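This account rests on a few compounds, and the source may have more. Where it says the series, first, only, none or still open, it means among the compounds named here.

Compound 1 (`CCc1ccc2[nH]c(=O)c(CN(Cc3ccc(F)cc3)Cc3ccc(C(C)(C)C)cc3)cc2c1`) gives > 33000 nM in a toxicity assay on MDCK cells (Canis lupus familiaris) for cytotoxicity, read by crystal violet staining, with a stated time of 48 h; on this read-out higher numbers stand for lower toxicity in this test and lower numbers for higher toxicity in this test
Compound 2 (`CCCc1ccc2[nH]c(=O)c(CN(Cc3ccc(F)cc3)Cc3ccc(C(C)(C)C)cc3)cc2c1`) gives 8400 nM
Compound 3 (`CCc1ccc2[nH]c(=O)c(CN(Cc3ccc(F)cc3)Cc3cccc4ccccc34)cc2c1`) gives > 5000 nM

Going by these compounds, compound 1 gives > 33000 nM as a limit of the assay and not a number, so its exact place on the scale is unknown. Compound 3 gives > 5000 nM and this is also a limit. Only compound 2 gives a true number, 8400 nM in this assay.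

Compound 4 (`CCc1ccc2[nH]c(=O)c(CN(Cc3ccc(O)cc3)Cc3ccc(C(C)(C)C)cc3)cc2c1`) differs from compound 1 in one place: hydroxy in place of fluoro on an aromatic carbon, which turns 4-fluorobenzyl into 4-hydroxybenzyl. Going by the values given here, no measured step changes this group, so the guidance is indirect. The closest guide is an at least 3.9-fold lower number from compound 1 to compound 2 (0.59 log units; beyond the scatter), which came from methyl in place of hydrogen on a saturated chain carbon and shows that one small edit can bring the number down. The other measured step, a step that the two limits leave unreadable from compound 1 to compound 3, gives no usable size.

A small move toward a lower number is therefore expected, perhaps none beyond the scatter. The expected step runs an at least 1.3-fold lower number from compound 1 to compound 4 (0.12 log units; that floor lies within the scatter) in this assay. For compound 4 the estimated value is 25000 nM with an expected range of 8000 nM to 50000 nM.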

Compound 4, half-maximal cytotoxic concentration: > 10000 nM
Compound 4 ended at the assay's limit (the forecaster's own chance of this, stated with the estimate: 50%); the middle value is on the limit's open side.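

Compound 4 gives > 10000 nM in this assay, which is a limit and not a number. Compound 1 gives > 33000 nM, also a limit, so the step between compound 1 and compound 4 cannot be read. The compounds shown leave open how far, if at all, hydroxy in place of fluoro shifts the true concentration.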